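The source may report more compounds than this note shows. Statements on the series, on what has been measured and on what is new or still open speak of the compounds shown alone.

Working notes on the series: three compounds sharing one core have numbers so far in a physicochemical assay for solubility, in phosphate buffer, measured as kinetic solubility; a lower number here means a less soluble compound, a higher number a more soluble compound. Compound 1 `CCC(/C=C1\OC(=O)NC1=O)(CC)c1ccc(-c2ccc3cccc(F)c3c2)[nH]c1=O` gives 32600 nM. Compound 3 `O=C1NC(=O)/C(=C/C2(c3ccc(-c4ccc5cccc(F)c5c4)[nH]c3=O)CCCC2)O1` gives 24500 nM, within the scatter of compound 1. Compound 2 `CC(C)C(c1ccc(-c2ccc3cccc(F)c3c2)[nH]c1=O)C1NC(=O)NC1=O` gives 10600 nM, the lowest of the three, and its gap to each of the other two lies beyond the scatter.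

The next compound to read is compound 4 `CC(C)C(c1ccc(-c2ccc3cccc(F)c3c2)[nH]c1=O)C1C(=O)NC(=O)N1C`, which differs from compound 2 in one place: 2,5-dioxoimidazolidin-4-yl becomes 3-methyl-2,5-dioxoimidazolidin-4-yl. The change is methyl in place of hydrogen on an amide-type nitrogen in a ring.

Among the compounds with values here, no measured pair shows this change, so the data give no direct size for it. A small upward move in this assay is expected, quite possibly none beyond the scatter. The expected step is a 1.3-fold higher number from compound 2 to compound 4 (0.12 log units; within the scatter). The width of the range follows the measured spread, which runs from compound 2 at 10600 nM to compound 1 at 32600 nM. For compound 4 the estimate is 14000 nM, with an expected range of 6500 nM to 30000 nM.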

Compound 4, solubility: 17900 nM
Compound 4: middle estimate off by 1.3-fold (0.11 log units), on the low side, within the range that was stated.
By their numbers in this assay, from the lowest: compounds 2, 4, 3 and 1 (each within the scatter of the next, the first and the last beyond it).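

In this assay, within the data shown here, the pair gives the first direct reading of methyl in place of hydrogen on an amide-type nitrogen in a ring: a 1.7-fold higher number from compound 2 to compound 4 (0.23 log units; within the scatter). In this pair, the amide hydrogen at this position, next to the ring atom that bears a large group, can therefore give way to methyl without a difference that can be separated from the scatter. The data shown offer no measured basis for explaining the size of this step.

A single pair cannot show whether this reading extends to larger groups: a longer chain such as ethyl, or a chain ending in an amine or a carboxylic acid, on the same nitrogen could stay within the scatter of compound 2 or move beyond it in this assay. Among these compounds, also open is whether methyl on the ring nitrogen of compound 1 or compound 3 would give a step of similar size, since the series holds only one pair for this change.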